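Pyridin-3-yl for phenyl on the acyl carbonyl

This account rests on a few compounds, and the source may have more. Where it says the series, first, only, none or still open, it means among the compounds named here.

Measured so far:
Compound 1 `CCC(=O)n1nc(C)c(-c2ccc(Cl)c(Cl)c2)c1N`; in an assay on Sf9 cells for inhibition of inhibitor of nuclear factor kappa-B kinase subunit epsilon (Homo sapiens), read by ADP-Glo, with a stated time of 60 min (on this read-out higher numbers stand for weaker inhibition and lower numbers for stronger inhibition), compound 1 gives > 100000 nM, a limit of the assay.
Compound 2 `Cc1nn(C(=O)c2ccccc2)c(N)c1-c1ccc(Cl)c(Cl)c1`; in this assay compound 2 gives > 100000 nM, again a limit.

Compound 2 thus stands at the limit of this assay, as does compound 1 (the limit of > 100000 nM in this assay, at which 2 of the 2 values shown sit); the step that the two limits leave unreadable from compound 1 to compound 2 is therefore unreadable. Compound 3 `Cc1nn(C(=O)c2cccnc2)c(N)c1-c1ccc(Cl)c(Cl)c1` differs from compound 2 by pyridin-3-yl in place of phenyl on a carbonyl carbon. Within the data shown here, no measured step reads on this change, and both measured values are limits, so no direction is known. Compound 3 is expected to stay at the limit, with an expected step of a number no higher from compound 2 to compound 3 (the limit leaves the size open). The estimate for compound 3 is 100000 nM, between 30000 nM and 300000 nM.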

Compound 3, half-maximal inhibitory concentration: > 100000 nM
Compound 3: only a limit was reported; the forecaster's own chance of this, stated with the estimate: 85%; the middle value sits exactly at the limit.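

Compound 3 joins compound 1 and compound 2 at a limit, so no step among the three can be read in this assay: the limit of > 100000 nM in this assay, at which 3 of the 3 values shown sit.

From the compounds shown here alone, how these acyl groups on the shared core rank against each other stays open, as does whether any of them gives measurable inhibition.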